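Benzyl ring substituent swap, compound 1 to compound 4

This account rests on a few compounds, and the source may have more. Where it says the series, first, only, none or still open, it means among the compounds named here.

Compound 1 `Cc1cc(S(=O)(=O)/N=C(\N)n2nccc2-c2ccccc2)c(SCc2cccc(Cl)c2)cc1Cl` sits at the top of the three numbers in an ADME assay on microsomes from liver (Homo sapiens) for metabolic stability, read by LC-MS, using NADPH, tested at 5 uM (a lower number here means that the compound disappears faster, a higher number that the compound lasts longer), with 0.309 h, though its steps to the other two stay within the scatter. Compound 3 `Cc1cc(-c2ccccc2)n(/C(N)=N/S(=O)(=O)c2cc(C)c(Cl)cc2SCc2cccc(Cl)c2)n1` gives 0.205 h and compound 2 `Cc1cc(-c2ccccc2)n(/C(N)=N/S(=O)(=O)c2cc(C)c(Cl)cc2SCc2cccc(C(F)(F)F)c2)n1` gives 0.169 h. Within the data shown here, the step of a 1.5-fold lower number from compound 1 to compound 3 (0.18 log units; within the scatter) and the step of a 1.2-fold higher number from compound 2 to compound 3 (0.08 log units; within the scatter) are the only two single-point steps in the set, and neither leaves the scatter.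

Compound 4 `Cc1ccc(CSc2cc(Cl)c(C)cc2S(=O)(=O)/N=C(\N)n2nccc2-c2ccccc2)cc1` differs from compound 1 by 4-methylphenyl in place of 3-chlorophenyl on a saturated chain carbon bound to a sulfur. The step that bears on it most directly is a 1.2-fold higher number from compound 2 to compound 3 (0.08 log units; within the scatter), since that one also exchanges a substituent on the benzyl ring of the benzylsulfanyl group; it moved nothing beyond the scatter. The step of a 1.5-fold lower number from compound 1 to compound 3 (0.18 log units; within the scatter) concerns a different ring and likewise stayed within the scatter. Nothing in the series shows a substituent change on this benzyl ring shifting the half-life beyond repeat variation, so no step beyond the scatter is expected for a 1.1-fold lower number from compound 1 to compound 4 (0.04 log units; within the scatter). Compound 4 is therefore estimated at 0.28 h, with a likely range of 0.14 h to 0.56 h.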

Compound 4, half-life: 0.13 h
Compound 4: the middle estimate sits 2.2-fold (0.33 log units) above what was measured, outside the stated range (below it).
By their numbers in this assay, from the lowest: compounds 4, 2, 3 and 1 (each within the scatter of the next, the first and the last beyond it).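

In this assay, among these compounds, the exchange of 3-chlorophenyl for 4-methylphenyl on a saturated chain carbon bound to a sulfur gives a 2.4-fold lower number from compound 1 to compound 4 (0.38 log units; beyond the scatter) and is the first single-place step to pass beyond the scatter. The step of a 1.2-fold higher number from compound 2 to compound 3 (0.08 log units; within the scatter) also falls on this benzyl ring and stays within the scatter, so the half-life at this position responds to some substituent exchanges and not to others, though that step sits on a different core and involves a different pair of groups. No measurement on hand bears on why this exchange moves the half-life.

Chloro leaves and methyl enters at a different ring position in one change, so the compounds shown do not separate the identity of the substituent from its location on the ring. Also open, on these data alone, are how a plain phenyl, or a phenyl carrying a methoxy group or an amine, would read at this place, and whether the same exchange gives a step of similar size on the core of compound 3.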